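The compounds below may be only part of what the source reports. "The series", "measured", "known", "first", "only" and "open" are said of these compounds alone.

Measured compounds:
- compound 1 `CC(C(=O)NCc1ccc(C(F)(F)F)nc1N1CCC(O)CC1)c1ccc(NS(C)(=O)=O)c(F)c1`: "not active" (no number reported)
- compound 2 `CC(=O)OC1CCN(c2nc(C(F)(F)F)ccc2CNC(=O)C(C)c2ccc(NS(C)(=O)=O)c(F)c2)CC1`: 4 nM

In a functional assay on CHO-K1 cells for antagonist activity at transient receptor potential cation channel subfamily V member 1 (Homo sapiens), read by FLIPR (a higher number here means a weaker inhibitor, a lower number a stronger inhibitor), compound 2 gives 4 nM; compound 1 gives "not active" (no number reported) in this assay, with no number to place it. Compound 2 therefore stands alone as the only numbered result, and its value marks it as a strong inhibitor. Compound 3 `CC(C(=O)NCc1ccc(C(F)(F)F)nc1N1CCCCCCC1)c1ccc(NS(C)(=O)=O)c(F)c1` is the next compound to be tested. It differs from compound 2 in one place: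

a group of 8 heavy atoms (7 carbon, 1 nitrogen; one eight-membered non-aromatic ring with 1 hetero atom) in place of a group of 10 heavy atoms (7 carbon, 1 nitrogen, 2 oxygen; one six-membered non-aromatic ring with 1 hetero atom), on an aromatic carbon

For the measured compounds named here, no pair of measured compounds shares a single change of this kind, so the size of the step cannot be read from existing data. Because compound 2 gives 4 nM, the new compound starts from a potent reference, and a moderate loss beyond the scatter is expected. The step of a 3.0-fold higher number from compound 2 to compound 3 (0.48 log units; beyond the scatter) is the expected change. Compound 3 is expected to give about 12 nM, within a range from 2.5 nM to 60 nM.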

Compound 3, inhibition constant: 0.7 nM
The estimate for compound 3 lay 17-fold (1.23 log units) above the measured number; measured number below the stated range.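

In this assay the eight-membered ring with one nitrogen, in place of the 4-acetoxypiperidin-1-yl group, gives a 5.7-fold lower number from compound 2 to compound 3 (0.76 log units; beyond the scatter) at this position, a modest change beyond the scatter. The aromatic carbon next to the ring nitrogen therefore accepts a larger ring, and the acetoxy group is not needed for strong inhibition in this series. No measurement shown accounts for the lower number.

This one step both enlarges the ring and removes the acetoxy group, and the compounds shown do not separate those two changes. They also leave open how an unsubstituted piperidine, a seven-membered azepane or an open-chain dipropylamine would behave at the same place.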